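A few compounds are considered here, and "the series" means these few. Any claim that something is new, unique, unknown or untested is made for them only; others in the source may bear on it.

In a physicochemical assay for solubility, read by LC-MS, in phosphate buffer, with a stated time of 24 h, at pH 7.4 (on this read-out higher numbers stand for higher solubility and lower numbers for lower solubility), compound 1 `Cc1nccn1-c1cnc(NCc2c(F)ccc3c2CCO3)c2cn[nH]c(=O)c12` gives 7000 nM, the second highest of the three numbers at hand. Compound 2 `O=C1c2ccccc2CN1c1cnc(NCc2c(F)ccc3c2CCO3)n2cnnc12` gives 4000 nM, within the scatter of compound 1, while compound 3 `C[C@@H]1CC(=O)N(c2cnc(NCc3c(F)ccc4c3CCO4)n3cnnc23)C1` gives 130000 nM. Compound 4 `Cc1nc(CO)ccc1-c1cnc(NCc2c(F)ccc3c2CCO3)c2cn[nH]c(=O)c12` differs from compound 1 in one place: 6-(hydroxymethyl)-2-methylpyridin-3-yl in place of 2-methyl-1H-imidazol-1-yl on an aromatic carbon. Within the data shown here, only one measured step bears on this, and it lies on a different core: a 33-fold higher number from compound 2 to compound 3 (1.51 log units; beyond the scatter), where the smaller group gave the higher number. In compound 4 the entering group is the larger one, so in this assay a more modest move to a lower number is expected, with the caveat that this rests on a single step. The expected change is a 2.8-fold lower number from compound 1 to compound 4 (0.45 log units; beyond the scatter). Compound 4 is estimated at 2500 nM, with an expected range of 500 nM to 12000 nM.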

Compound 4, solubility: 3000 nM
Compound 4: middle estimate off by 1.2-fold (0.08 log units), on the low side; low and high end bracket the measured number.
By their numbers in this assay, from the lowest: compounds 4, 2 and 1 (each within the scatter of the next, the first and the last beyond it); then compound 3.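

In this assay, among these compounds, the first step on the core of compound 1 is a 2.3-fold lower number from compound 1 to compound 4 (0.37 log units; beyond the scatter), so exchanging one aromatic ring for a larger one carrying a hydroxymethyl group changes the number only modestly at this place. Among the compounds shown here, the single earlier step, on a different core, was large and involved a non-aromatic ring. Nothing measured here explains the lower number.

As far as these compounds go, it remains open what the hydroxymethyl group contributes apart from the pyridine ring. From the compounds shown here alone, it is also open how a non-aromatic amine such as morpholine would read on this aromatic carbon of the same core.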